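A few compounds are considered here, and "the series" means these few. Any claim that something is new, unique, unknown or untested is made for them only; others in the source may bear on it.

Measured compounds:
compound 1, `COCC(COC)N(C)c1nc(C)nc2c1nnn2-c1ccc(C(C)C)cc1Br`, 21.3 nM;
compound 2, `CCCCN(CC)c1nc(C)nc2c1nnn2-c1c(Cl)cc(OC)cc1OC`, 4.4 nM;
compound 3, `CCCCN(CC)c1nc(C)nc2c1nc(C(F)(F)F)n2-c1ccc(C(C)C)cc1Br`, 1.4 nM.

In an in vitro assay on 293-EBNA cells for binding affinity to corticotropin-releasing factor receptor 1 (Homo sapiens) (on this read-out higher numbers stand for weaker inhibition and lower numbers for stronger inhibition), compound 1 gives the highest of the three numbers. Compound 2 sits at a lower number, and compound 3 at a lower number still, each gap lying beyond the usual scatter of this assay. Compound 4, `CCOCC(COCC)Oc1nc(C)nc2c1nnn2-c1ccc(C(C)C)cc1Br`, is not yet measured. It differs from compound 1 in one place: a group of 10 heavy atoms (7 carbon, 3 oxygen; no ring) in place of a group of 9 heavy atoms (6 carbon, 1 nitrogen, 2 oxygen; no ring), on an aromatic carbon. Among the compounds with values here, no measured pair shows this kind of change, so the size of the step rests on judgement alone. The author expects a modest shift toward a higher number, possibly not beyond the scatter, so that the step of a 2.1-fold higher number from compound 1 to compound 4 (0.32 log units; beyond the scatter) is small. Compound 4 is therefore estimated at 45 nM, within a range from 15 nM to 150 nM.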

Compound 4, inhibition constant: 39.7 nM
Estimate against measurement, compound 4: 1.1-fold (0.05 log units) above, within the range that was stated.
By their numbers in this assay, from the lowest: compound 3; then compound 2; then compounds 1 and 4 (each within the scatter of the next).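

In this assay, the group of 10 heavy atoms in place of the group of 9 heavy atoms on this aromatic carbon gives a 1.9-fold higher number from compound 1 to compound 4 (0.27 log units; within the scatter). The two groups share the same counts of hydrogen-bond donors and acceptors, and this single pair shows that the exchange leaves the read-out indistinguishable from repeat scatter on the core of compound 1. No measurement bears on the reason for this result. The compounds shown leave open how a thioether or a morpholine would read at this position. They also leave open whether the same exchange would give a similar step on the core of compound 3.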